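A few compounds are considered here, and "the series" means these few. Any claim that something is new, unique, unknown or untested is made for them only; others in the source may bear on it.

Three compounds of the series share one core and differ only on the sulfonyl sulfur. Compound 1 `O=C(Nc1ccc(S(=O)(=O)N2CCOCC2)cc1)C1C(C(=O)O)[C@H]2CC[C@@H]1O2` gives 24200 nM in a functional assay on A549 cells (Homo sapiens) for cytotoxicity, read by MTT assay, with a stated time of 48 h; a lower number here means a stronger inhibitor, a higher number a weaker inhibitor. Compound 2 `O=C(Nc1ccc(S(=O)(=O)NC2CC2)cc1)C1C(C(=O)O)[C@H]2CC[C@@H]1O2` gives 34300 nM in the same assay, and compound 3 `CCN1CCN(S(=O)(=O)c2ccc(NC(=O)C3C(C(=O)O)[C@H]4CC[C@@H]3O4)cc2)CC1` gives 28400 nM. The number of compound 3 lies between those of compound 1 and compound 2, and all three sit within the scatter of one another: a 1.4-fold higher number from compound 1 to compound 2 (0.15 log units; within the scatter), a 1.2-fold higher number from compound 1 to compound 3 (0.07 log units; within the scatter), a 1.2-fold lower number from compound 2 to compound 3 (0.08 log units; within the scatter).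

The next compound, compound 4 `O=C(Nc1ccc(S(=O)(=O)NC2CCCCC2)cc1)C1C(C(=O)O)[C@H]2CC[C@@H]1O2`, takes the step (cyclohexylamino in place of 4-ethylpiperazin-1-yl on a sulfonyl sulfur). Among the measured compounds shown here, the steps that bear on it are the two exchanges of the group on the sulfonyl sulfur that have been measured, a 1.2-fold lower number from compound 2 to compound 3 (0.08 log units; within the scatter) and a 1.2-fold higher number from compound 1 to compound 3 (0.07 log units; within the scatter), both within the scatter. An acyclic or cyclic amino group and a cyclic tertiary amino group at this position have so far given no step beyond the scatter, and cyclohexylamino is most nearly matched by the cyclopropylamino of compound 2, whose value is 34300 nM.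

For compound 4 the expected value in this assay is therefore 31000 nM, in the range 15000 nM to 65000 nM, which means an expected step of a 1.1-fold higher number from compound 3 to compound 4 (0.04 log units; within the scatter), not beyond the scatter.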

Compound 4, half-maximal inhibitory concentration in the A549 assay: 36200 nM
The estimate for compound 4 lay 1.2-fold (0.07 log units) below the measured number; the range from low to high includes it.
By their numbers in the A549 assay, from the lowest: compounds 1, 3, 2 and 4 (each within the scatter of the next).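

In the A549 assay the sulfonyl sulfur takes cyclohexylamino without a step beyond the scatter from any of the three earlier groups: a 1.3-fold higher number from compound 3 to compound 4 (0.11 log units; within the scatter) and a 1.5-fold higher number from compound 1 to compound 4 (0.17 log units; within the scatter) are both within it. The change of cyclohexyl in place of cyclopropyl on a sulfonamide nitrogen, the first exchange here made on that nitrogen with the hydrogen-bond donor kept, gives a 1.1-fold higher number from compound 2 to compound 4 (0.02 log units; within the scatter) and so also stays within the scatter, which means a ring of carbon only and a ring with hetero atoms are not told apart at this position by the compounds shown. In a physicochemical assay for lipophilicity (on this read-out higher numbers stand for higher lipophilicity and lower numbers for lower lipophilicity), compound 3 gives 0.4 and compound 4 gives 0.2 in a step of a number 0.20 log units lower from compound 3 to compound 4 (within the scatter) that is likewise within the scatter, so the same exchange separates the pair on neither read-out.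

As far as these compounds go, whether any group on the sulfonyl sulfur can move the number beyond the scatter stays open, for instance a plain amino group or a longer chain such as hexylamino, and so does the effect of a methyl ester in place of the carboxylic acid of the shared core. No measurement at hand explains why these exchanges leave the number within the scatter.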